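A few compounds are considered here, and "the series" means these few. Any claim that something is new, unique, unknown or untested is made for them only; others in the source may bear on it.

Working notes on the series. Three analogues of one shared core have been measured in a functional assay on HCT-116 cells (Homo sapiens) for antiproliferative activity, read by MTT assay, with a stated time of 72 h; a lower number here means a stronger inhibitor, a higher number a weaker inhibitor. Compound 1 `NC1=NC2(CCOCC2)N(OCCCOc2ccc(Cl)cc2)C(N)=N1` gives 690 nM in this assay; compound 2 `NC1=NC2(CCOCC2)N(OCCCOc2ccccc2Cl)C(N)=N1` gives 70 nM; compound 3 `COc1ccc(OCCCON2C(N)=NC(N)=NC23CCOCC3)cc1` gives 1500 nM. Compound 3 therefore stands highest of the three numbers, the nearest being compound 1 and the furthest compound 2. The steps behind this are a 2.2-fold higher number from compound 1 to compound 3 (0.34 log units; beyond the scatter), a 9.9-fold lower number from compound 1 to compound 2 (0.99 log units; beyond the scatter) and a 21-fold higher number from compound 2 to compound 3 (1.33 log units; beyond the scatter).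

The next compound, compound 4 `NC1=NC2(CCOCC2)N(OCCCOc2cccc(Br)c2)C(N)=N1`, is unmeasured. It differs from compound 3 in one place: 3-bromophenyl in place of 4-methoxyphenyl on an oxygen on a saturated carbon. Going by the values given here, no measured step carries a 3-bromophenyl, so no step bears on it directly. Among the compounds with values here, two steps bear on it indirectly: the chloro-for-methoxy comparison a 2.2-fold higher number from compound 1 to compound 3 (0.34 log units; beyond the scatter) and the change of ring position a 9.9-fold lower number from compound 1 to compound 2 (0.99 log units; beyond the scatter), both pointing to lower numbers for compounds without the methoxy. On that basis a step of a 6.0-fold lower number from compound 3 to compound 4 (0.78 log units; beyond the scatter) is expected in this assay, in the direction of a lower number. Compound 4 is estimated at 250 nM, with a range from 60 nM to 1000 nM.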

Compound 4, half-maximal inhibitory concentration: 40 nM
Beside the measured number, compound 4's estimate is 6.3-fold (0.80 log units) above it; the measured number lies below the stated range.
By their numbers in this assay, from the lowest: compounds 4 and 2 (each within the scatter of the next); then compound 1; then compound 3.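

In this assay, a low number at this position is not unique to the 2-chlorophenyl group: a 1.8-fold lower number from compound 2 to compound 4 (0.24 log units; within the scatter), so 3-bromophenyl and 2-chlorophenyl cannot be ordered here, while a 38-fold lower number from compound 3 to compound 4 (1.57 log units; beyond the scatter) and a 17-fold lower number from compound 1 to compound 4 (1.24 log units; beyond the scatter) are both large. Across the four compounds, the 4-chlorophenyl and 4-methoxyphenyl groups give the higher numbers and the 2-chlorophenyl and 3-bromophenyl groups the lower numbers, with no compound shown going against this. Ring position and halogen change together from compound 1 to compound 4, so that step cannot be assigned to either change alone.

No measurement available here accounts for the size of these steps. As far as these compounds go, it remains open whether 3-chlorophenyl or 2-bromophenyl would separate the halogen from its ring position, and whether an amine or carboxylic acid on the ring, or a longer chain, would keep the number low.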